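Selenium series: dropping the methoxy from compound 1

The source may hold more compounds than are shown below. What is called first, only, known or untested is meant among the compounds shown, and "the series" means these compounds.

Compound 1, `COc1ccc(CNc2nc([Se]C)nc3ccccc23)cc1`, is assessed in an ADME assay on 184B5 cells (Homo sapiens) for cytotoxicity, read by MTT assay, with a stated time of 72 h; a lower number here means a stronger inhibitor of growth, a higher number a weaker inhibitor of growth. In this assay compound 1 reaches only a limit, > 100000 nM. Compound 2, `COc1ccc(CNc2nc([SeH])nc3ccccc23)cc1`, likewise stops at a limit, > 100000 nM. Compound 3, `CCCCC[Se]c1nc([Se]CCCCC)c2ccccc2n1`, also gives only a limit, > 100000 nM. Within the data shown here, the single one-site step, a step that the two limits leave unreadable from compound 1 to compound 2, cannot be read because the limit of > 100000 nM in this assay, at which 3 of the 3 values shown sit, puts every value at the same edge of the assay. Compound 1 therefore stands at the limit alongside the others, with no ordering readable. Compound 4, `C[Se]c1nc(NCc2ccccc2)c2ccccc2n1`, differs from compound 1 by hydrogen in place of methoxy on an aromatic carbon. Among the measured compounds shown here, no measured step bears on this change. The expected step is a number no higher from compound 1 to compound 4 (the limit leaves the size open), most probably again a limit rather than a number. Compound 4 is accordingly estimated at 100000 nM, with a range from 50000 nM to 300000 nM.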

Compound 4, concentration for total growth inhibition: 12400 nM
Compound 4: the middle estimate sits 8.1-fold (0.91 log units) above what was measured; measured number below the stated range.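

In this assay, among these compounds, hydrogen in place of methoxy gives an at least 8.0-fold lower number from compound 1 to compound 4 (0.90 log units; beyond the scatter), the first readable step. Compound 4 alone gives a number rather than a limit, so this aromatic carbon is a position where a single change moves the read-out. Only a minimum size can be read for the step because compound 1 stays at a limit: the limit of > 100000 nM in this assay, at which 3 of the 4 values shown sit.

On these data alone, whether a fluorine, a chlorine or a hydroxyl at this carbon also gives a number remains open. So does the effect of hydrogen in place of methyl on the selenium of compound 4.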